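Cytotoxicity of a diaryl ether pyrimidine series on MT4 cells

The source may report more compounds than this note shows. Statements on the series, on what has been measured and on what is new or still open speak of the compounds shown alone.

The measured compounds:
- compound 1, `CCCCNc1cc(Oc2c(OC)cc3cc(C#N)ccc3c2OC)nc(Nc2ccc(C#N)cc2)n1`, in an ADME assay on MT4 cells (Homo sapiens) for cytotoxicity, read by MTT assay, with a stated time of 5 days (on this read-out higher numbers stand for lower toxicity in this test and lower numbers for higher toxicity in this test), compound 1 gives > 125000 nM, a limit of the assay
- compound 2, `COc1cc2cc(C#N)ccc2c(OC)c1Oc1cc(NCC(C)C)nc(Nc2ccc(C#N)cc2)n1`, in this assay compound 2 gives > 125000 nM, a limit of the assay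
- compound 3, `COc1cc2cc(C#N)ccc2c(OC)c1Oc1cc(NC2CCC2)nc(Nc2ccc(C#N)cc2)n1`, in this assay compound 3 gives > 125000 nM, a limit of the assay

Compound 2 stands where every measured compound stands in this assay: at the limit, with no number behind it, as the evidence the limit of > 125000 nM in this assay, at which 3 of the 3 values shown sit, records. The steps between the measured compounds are therefore unreadable: a step that the two limits leave unreadable from compound 1 to compound 2, a step that the two limits leave unreadable from compound 1 to compound 3 and a step that the two limits leave unreadable from compound 2 to compound 3, none of them with a size.

Compound 4, `COc1cc2cc(C#N)ccc2c(OC)c1Oc1cc(NCCC2=CCCCC2)nc(Nc2ccc(C#N)cc2)n1`, has not yet been measured in this assay. It differs from compound 2 in one place: (cyclohex-1-en-1-yl)methyl in place of isopropyl on a saturated chain carbon bound to a nitrogen on an aromatic ring. The measured steps all concern exchanges of small saturated chains or a small ring on the nitrogen on the aromatic ring and bear only loosely on this change, which introduces a larger group with a six-membered non-aromatic ring. Since every measured step is unreadable, no size can be drawn from them.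

Compound 4 is therefore expected to remain near the limit, giving 125000 nM, within 30000 nM to 300000 nM. The expected step is a number no higher from compound 2 to compound 4 (the limit leaves the size open), most likely none beyond the scatter.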

Compound 4, half-maximal cytotoxic concentration: > 125000 nM
Compound 4 was reported as a limit (the forecaster's own chance of this, stated with the estimate: 65%); the middle value lies on the limit itself.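

In this assay compound 4 gives > 125000 nM, a limit of the assay. With limits on both sides, the steps to compound 4 from compound 1, compound 2 and compound 3 cannot be read. The compounds shown leave open at what concentration any of them would turn cytotoxic to these cells, and whether the different groups on the nitrogen would separate them there at all.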